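Series notes: aryl swap on the five-membered ring of compound 1

A few compounds are considered here, and "the series" means these few. Any claim that something is new, unique, unknown or untested is made for them only; others in the source may bear on it.

Measured so far:
- Compound 1, `Cc1nc2cc(OC[C@H](O)CN3CCN(Cc4noc(-c5ccc(C(C)(C)C)cc5)n4)CC3)ccc2s1`, in a functional assay on mitochondria from heart for inhibition of peroxisomal acyl-coenzyme A oxidase 1 (Rattus norvegicus); on this read-out lower numbers stand for stronger inhibition and higher numbers for weaker inhibition: 180 nM
- Compound 2, `Cc1nc2cc(OC[C@H](O)CN3CCN(Cc4nc(-c5ccc(C(F)(F)F)cc5)sc4C)CC3)ccc2s1`, in this assay: 1500 nM
- Compound 3, `Cc1nc2cc(OC[C@H](O)CN3CCN(Cc4noc(-c5cccc(Cl)c5)n4)CC3)ccc2s1`, in this assay: 4120 nM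

Compound 1 gives the lowest number of the three in this assay; compound 2 sits nearer to it and compound 3 furthest away, both beyond the scatter. Among the measured compounds shown here, for compound 2 no single-point step from compound 1 exists, so the two values are only set side by side.

Compound 4, `Cc1nc2cc(OC[C@H](O)CN3CCN(Cc4noc(-c5cccc(F)c5)n4)CC3)ccc2s1`, differs from compound 1 in one place: 3-fluorophenyl in place of 4-(tert-butyl)phenyl on an aromatic carbon. For the measured compounds named here, the one step that bears on it is the exchange of the same group for 3-chlorophenyl, a 23-fold higher number from compound 1 to compound 3 (1.36 log units; beyond the scatter), a large loss in this assay. Replacing 4-(tert-butyl)phenyl with 3-fluorophenyl keeps the halogen in the same ring position and takes away the same group, so a step of similar size and direction is expected: a 28-fold higher number from compound 1 to compound 4 (1.44 log units; beyond the scatter). Compound 4 is therefore estimated at 5000 nM in this assay, with a range from 1500 nM to 16000 nM.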

Compound 4, half-maximal inhibitory concentration: 13400 nM
Compound 4: middle estimate off by 2.7-fold (0.43 log units), on the low side; the measured number falls inside the stated range.
By their numbers in this assay, from the lowest: compound 1; then compound 2; then compound 3; then compound 4.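

In this assay, the aryl group on this five-membered ring still responds to a change of halogen once 4-(tert-butyl)phenyl has gone: fluoro in place of chloro gives a further, modest loss (a 3.3-fold higher number from compound 3 to compound 4 (0.51 log units; beyond the scatter)). That step is small beside the full exchange (a 74-fold higher number from compound 1 to compound 4 (1.87 log units; beyond the scatter)), so among these compounds most of the loss lies in leaving 4-(tert-butyl)phenyl, and the choice of halogen adds only a smaller part. Nothing available explains either step.

Still open, as far as these compounds go, is whether the loss follows from removing the tert-butyl group or from moving the substituent, which 4-chlorophenyl or 4-fluorophenyl at this place would separate. Also open, from the compounds shown here alone, is how this position would respond to a phenyl ring bearing an amine or a carboxylic acid.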